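A few compounds are considered here, and "the series" means these few. Any claim that something is new, unique, unknown or untested is made for them only; others in the source may bear on it.

Working notes on the series. In a functional assay on NCI-H1975 cells (Homo sapiens) for antiproliferative activity, read by CCK-8 assay, with a stated time of 72 h (a lower number here means a stronger inhibitor of growth, a higher number a weaker inhibitor of growth), compound 1 `CCC1C(=O)N(C)c2cnc(Nc3ccc(S(=O)(=O)NCC(C)C)cc3)nc2N1c1ccn(C)n1` gives 15000 nM. Compound 2 `CCC1C(=O)N(C)c2cnc(-n3ccc4cc(C(=O)NC(C)C)ccc43)nc2N1c1ccn(C)n1` gives 12200 nM, and these two values lie within the usual scatter of each other, so neither compound can be placed ahead of the other. Compound 3 `CCNC(=O)c1ccc2c(ccn2-c2ncc3c(n2)N(c2ccn(C)n2)C(CC)C(=O)N3C)c1` has not yet been measured. It differs from compound 2 in one place: hydrogen in place of methyl on a saturated chain carbon bound to an amide-type nitrogen and a saturated chain carbon. This is hydrogen in place of methyl on a saturated chain carbon bound to an amide-type nitrogen and a saturated chain carbon, which turns isopropylcarbamoyl into ethylcarbamoyl. Among the compounds with values here, no measured pair shows this change, so the data give no direct guide to its size. No shift beyond the scatter is expected in this assay, in either direction. The expected step, a 1.1-fold lower number from compound 2 to compound 3 (0.04 log units; within the scatter), is an estimate that stays within the scatter. For compound 3 the estimated value is 11000 nM, with an expected range of 5500 nM to 22000 nM.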

Compound 3, concentration for 50% growth inhibition: "not active" (no number reported)
Compound 3 has no reported number here; there is nothing to compare the estimate with.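

In this assay, within the data shown here, compound 3 is reported as "not active" with no number, so no step from compound 2 to compound 3 can be read. The compounds shown leave open how far isopropylcarbamoyl to ethylcarbamoyl shifts growth inhibition. No supporting data bear on this result.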